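Moving the ring nitrogen of a thiazole on a lactam core

A few compounds are considered here, and "the series" means these few. Any claim that something is new, unique, unknown or untested is made for them only; others in the source may bear on it.

Measured so far:
Compound 1, `O=C(NCc1ccc(Cl)cc1Cl)[C@@H]1CCC(=O)N1c1cccs1`: 720 nM
Compound 2, `O=C(NCc1ccc(Cl)cc1Cl)[C@@H]1CCC(=O)N1c1nccs1`: 2390 nM

Both compounds were tested in an assay on HEK293 cells for displacement of a labelled ligand from P2X purinoceptor 7 (Homo sapiens), read by scintillation counting, with a stated time of 1 h; on this read-out lower numbers stand for stronger inhibition and higher numbers for weaker inhibition. Compound 2 gives the higher of the two numbers, that is the weaker of the two: replacing thiophen-2-yl by 1,3-thiazol-2-yl on the amide-type nitrogen of the shared core gave a 3.3-fold higher number from compound 1 to compound 2 (0.52 log units; beyond the scatter).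

Compound 3, `O=C(NCc1ccc(Cl)cc1Cl)[C@@H]1CCC(=O)N1c1cscn1`, keeps the same atoms but joins them differently: 1,3-thiazol-4-yl in place of 1,3-thiazol-2-yl on an amide-type nitrogen in a ring. Among the measured compounds shown here, no measured step shows what moving the nitrogen of the thiazole to another position does here; the only step at hand, from compound 1 to compound 2, concerns adding that nitrogen, not moving it, so it gives no direction for the change to compound 3. Compound 3 is therefore expected to lie near compound 2, with a 1.2-fold lower number from compound 2 to compound 3 (0.08 log units; within the scatter) as a step that may fall inside the scatter. The estimate for compound 3 in this assay is 2000 nM, with a range from 600 nM to 7000 nM.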

Compound 3, half-maximal inhibitory concentration: 384 nM
Compound 3: middle estimate off by 5.2-fold (0.72 log units), on the high side; the whole stated range lies above it.
By their numbers in this assay, from the lowest: compounds 3 and 1 (each within the scatter of the next); then compound 2.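

On the amide-type nitrogen of the shared core, where the ring nitrogen of the thiazole sits matters, not only whether it is there: 1,3-thiazol-4-yl in place of 1,3-thiazol-2-yl gave a 6.2-fold lower number from compound 2 to compound 3 (0.79 log units; beyond the scatter) even though the two groups have the same atoms. The weaker result of compound 2 therefore does not extend to thiazoles in general, since 1,3-thiazol-4-yl in place of thiophen-2-yl gave a 1.9-fold lower number from compound 1 to compound 3 (0.27 log units; within the scatter) and that step stays within the usual scatter. Nothing available explains why the nitrogen's position makes this difference.

Still open, going by these compounds, is how a 1,3-thiazol-5-yl group or a pyridin-2-yl ring would read at this place, and whether a methyl or an amine on the 1,3-thiazol-4-yl ring would shift the number. The dichlorophenyl group is the same in all three compounds, so these steps say nothing about changes there.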